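Removing a Chloro Group From Two Related Cores

The compounds below may be only part of what the source reports. "The series", "measured", "known", "first", "only" and "open" are said of these compounds alone.

compound 1 `Cc1cc(C)nc(SCc2cc(=O)c3cc(Cl)ccc3o2)n1` — > 25000 nM
compound 2 `Cc1cc(C)n2nc(SCc3cc(=O)c4cc(Cl)ccc4o3)nc2n1` — > 25000 nM
compound 3 `Cc1cc(C)nc(SCc2cc(=O)c3ccccc3o2)n1` — > 25000 nM

All three measured compounds were tested in a functional assay on MDA-MB-435S cells (Homo sapiens) for cytotoxicity, read by MTT assay, with a stated time of 72 h; a lower number here means a stronger inhibitor, a higher number a weaker inhibitor. Compound 1 gives > 25000 nM, which is a limit of the assay and not a number. Compound 3 gives > 25000 nM, again only a limit. Compound 2 gives > 25000 nM, likewise a limit. The three values therefore share one feature: the limit of > 25000 nM in this assay, at which 3 of the 3 values shown sit.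

Compound 1 and compound 3 differ in a single place, (hydrogen in place of chloro on an aromatic carbon). The step that the two limits leave unreadable from compound 1 to compound 3 cannot be read, since both ends are limits. The difference between the core of compound 1 and the core of compound 2 is not broken down here.

Compound 4 `Cc1cc(C)n2nc(SCc3cc(=O)c4ccccc4o3)nc2n1` has not yet been measured in this assay. It stands to compound 2 as compound 3 stands to compound 1: hydrogen in place of chloro on an aromatic carbon. The surroundings of the changed position are described in the same words for both pairs, so this is the same change made on the second core.

With compound 2 giving only the limit > 25000 nM, and with the step from compound 1 to compound 3 unreadable, there is no measured movement on which to build a different expectation for compound 4. Compound 4 is therefore expected to remain at the limit as well, with a step that the limit leaves unreadable from compound 2 to compound 4 as the estimated step. The estimated value for compound 4 is 40000 nM, within an expected range from 15000 nM to 100000 nM.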

Compound 4, half-maximal inhibitory concentration: > 25000 nM
Compound 4: no number, only a limit; the forecaster's own chance of this, stated with the estimate: 85%; the middle value is on the limit's open side.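

In this assay compound 4 gives > 25000 nM, which is a limit of the assay and not a number. No step can be read between compound 2 and compound 4, since both ends are limits, and all the results share one feature: the limit of > 25000 nM in this assay, at which 4 of the 4 values shown sit.

The compounds shown leave open whether hydrogen in place of chloro makes any difference on either core, and how strong any of the four compounds actually is.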